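The source may report more compounds than this note shows. Statements on the series, on what has been measured and on what is new or still open speak of the compounds shown alone.

Compound 1 `CCC[C@@H]1O[C@H](COCc2ccccc2)[C@@H](OCc2ccccc2)[C@H](OCc2ccccc2)[C@@H]1O` — in a functional assay on HL-60 cells (Homo sapiens) for antiproliferative activity, read by MTT assay (on this read-out lower numbers stand for stronger inhibition and higher numbers for weaker inhibition), compound 1 gives "not active" (no number reported).
Compound 2 `CCC[C@@H]1O[C@H](COCc2ccccc2)[C@H](OCc2ccccc2)[C@H](OCc2ccccc2)[C@H]1O` — in this assay compound 2 gives "not active" (no number reported).
Compound 3 `CCC[C@@H]1O[C@H](COCc2ccccc2)[C@@H](OCc2ccccc2)[C@H](OCc2ccccc2)[C@H]1O` — in this assay compound 3 gives 11700 nM.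

The three measured compounds share one core and differ only in how their substituents are arranged in space: the fact that compounds 1 and 2 differ only in the configuration as drawn, the fact that compounds 1 and 3 differ only in the configuration as drawn and (the fact that compounds 2 and 3 differ only in the configuration as drawn). Of the three, only compound 3 returns a number, and that number is weak; compound 2 and compound 1 return no number at all, so compound 2 stands among the compounds for which this assay reported no measurable inhibition.

Compound 4 `CC(C)C[C@@H]1O[C@H](COCc2ccccc2)[C@H](OCc2ccccc2)[C@H](OCc2ccccc2)[C@H]1O` is built from compound 2 by a small change on the side chain: methyl in place of hydrogen on a saturated chain carbon bound to two saturated chain carbons. In this assay, with no numbers for compound 2 to anchor a comparison, the step from compound 2 to compound 4 is best expected to be small, with no clear direction, and most likely to stay within the scatter of the assay rather than lift the compound into a measurable range.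

Compound 4 is therefore expected to give about 30000 nM, with a plausible range from 8000 nM to 120000 nM, and a real chance that the assay again returns no number.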

Compound 4, half-maximal inhibitory concentration: "not active" (no number reported)
No number was reported for compound 4; there is nothing to compare the estimate with.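

Compound 2 and compound 4 both come back without a number in this assay, so the step between them cannot be read. Nothing shown explains this result. The compounds shown leave open whether the same change from propyl to isobutyl would alter activity on the spatial arrangement of compound 3, the only one here that gives a number.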